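Bromo in place of iodo on the shared core

The compounds below may be only part of what the source reports. "The series", "measured", "known", "first", "only" and "open" are said of these compounds alone.

Measured compounds:
compound 1 `COc1cccc(-c2cc(C)c3ncc(CSCCc4ccccc4)n3c2)c1` — 20 ug/mL
compound 2 `Cc1cc(-c2cccc([N+](=O)[O-])c2)cn2c(CSCCc3ccccc3)cnc12` — >= 100 ug/mL
compound 3 `Cc1cc(I)cn2c(CSCCc3ccccc3)cnc12` — >= 0.8 ug/mL

The read-out throughout is an ADME assay on HEL cells (Homo sapiens) for cytotoxicity, with a stated time of 3 days; on this read-out higher numbers stand for lower toxicity in this test and lower numbers for higher toxicity in this test. Compound 1 gives 20 ug/mL. For compound 2 the value >= 100 ug/mL is a limit of the assay and not a number. For compound 3 the value >= 0.8 ug/mL is likewise a limit and not a number. Two of the three values shown are limits, so compound 3 cannot be ranked against compound 1 or compound 2; what is known of it is where its limit sits, (the limit of >= 0.8 ug/mL in this assay, at which 1 of the 3 values shown sits). For the measured compounds named here, the one readable step, an at least 5.0-fold higher number from compound 1 to compound 2 (0.69 log units; beyond the scatter), concerns a different change and does not involve compound 3. The steps a step that the limit leaves unreadable from compound 1 to compound 3 and a step that the two limits leave unreadable from compound 2 to compound 3 cannot be sized.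

Compound 4 `Cc1cc(Br)cn2c(CSCCc3ccccc3)cnc12` differs from compound 3 in one place: bromo in place of iodo on an aromatic carbon. Going by the values given here, no measured step bears on an exchange of bromo for iodo, and compound 3 itself is known only as a limit. Compound 4 is therefore expected to show a step that the limit leaves unreadable from compound 3 to compound 4 that remains within the scatter of this assay. Compound 4 is estimated at 4 ug/mL, with a range from 0.8 ug/mL to 20 ug/mL, and a real chance that only a limit is reported.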

Compound 4, minimum cytotoxic concentration: >= 2 ug/mL
Compound 4: no number, only a limit; the forecaster's own chance of this, stated with the estimate: 35%; the middle value lies beyond the limit too.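

In this assay, compound 4 gives >= 2 ug/mL, which is a limit and not a number. For the compounds shown here, no step from compound 1, compound 2 or compound 3 to compound 4 can be read. Still open, from the compounds shown here alone, is whether compound 3 and compound 4, with iodo and bromo, differ at all, and how either ranks against compound 1 or compound 2.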